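The source may hold more compounds than are shown below. What is called first, only, known or untested is meant among the compounds shown, and "the series" means these compounds.

For the measured compounds named here, in a functional assay on MDA-MB-231 cells (Homo sapiens) for antiproliferative activity, read by MTT assay, with a stated time of 48 h (on this read-out lower numbers stand for stronger inhibition and higher numbers for weaker inhibition), three compounds built on a shared core have numbers so far. Compound 1 `CN1CCN(c2ccc(-c3cc4c(N5CCN(S(=O)(=O)N6CCCCC6)CC5)ncnc4s3)cc2)CC1` gives 8130 nM, compound 2 `CCCNC(=O)N1CCN(c2ncnc3sc(-c4ccc(N5CCN(C)CC5)cc4)cc23)CC1` gives 8330 nM, and compound 3 `CN1CCN(c2ccc(-c3cc4c(N5CCN(C(=O)Nc6ccc(OC(F)(F)F)cc6)CC5)ncnc4s3)cc2)CC1` gives 4600 nM. Compound 3 thus stands within the scatter of both others, and the three form a single group on these numbers.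

Compound 4 `COc1ccccc1NC(=O)N1CCN(c2ncnc3sc(-c4ccc(N5CCN(C)CC5)cc4)cc23)CC1`, not yet measured, differs from compound 3 in one place: 2-methoxyphenyl in place of 4-(trifluoromethoxy)phenyl on an amide-type nitrogen. In words, this is 2-methoxyphenyl in place of 4-(trifluoromethoxy)phenyl on an amide-type nitrogen. The measured step closest to this change is a 1.8-fold lower number from compound 2 to compound 3 (0.26 log units; within the scatter), with 4-(trifluoromethoxy)phenyl in place of propyl on that same kind of nitrogen. The other is a 1.0-fold higher number from compound 1 to compound 2 (0.01 log units; within the scatter), with propylcarbamoyl in place of (piperidin-1-yl)sulfonyl on an amine nitrogen in a ring. Both steps lie within the scatter. Going by the values given here, no measured compound carries 2-methoxyphenyl, so the evidence is indirect, and three compounds are a narrow base. Even so, no shift beyond the scatter is expected in this assay. The expected step is a 1.3-fold higher number from compound 3 to compound 4 (0.12 log units; within the scatter). Compound 4 is estimated at 6000 nM, with an expected range from 2800 nM to 12000 nM.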

Compound 4, half-maximal inhibitory concentration: 23200 nM
The estimate for compound 4 lay 3.9-fold (0.59 log units) below the measured number, and the stated range ends below it.
By their numbers in this assay, from the lowest: compounds 3, 1 and 2 (each within the scatter of the next); then compound 4.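

In this assay, the group on the amide-type nitrogen now shows a change that goes beyond the scatter, whereas propyl and 4-(trifluoromethoxy)phenyl at this place had stayed within it: 2-methoxyphenyl in place of 4-(trifluoromethoxy)phenyl gives a 5.0-fold higher number from compound 3 to compound 4 (0.70 log units; beyond the scatter), and 2-methoxyphenyl in place of propyl gives a 2.8-fold higher number from compound 2 to compound 4 (0.44 log units; beyond the scatter). The comparison with the sulfonyl compound points the same way, with (2-methoxyphenyl)carbamoyl in place of (piperidin-1-yl)sulfonyl giving a 2.9-fold higher number from compound 1 to compound 4 (0.46 log units; beyond the scatter), so compound 4 stands apart from the three compounds that earlier formed a single group. Nothing measured here accounts for this separation.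

The compounds shown leave open whether the higher number goes with the methoxy group itself or with its place on the ring, a question that 4-methoxyphenyl or 2-(trifluoromethoxy)phenyl on the same nitrogen would help to settle. On these data alone, it also remains open whether plain phenyl or benzyl at this place would stay with the group of three or fall with compound 4.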